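This account rests on a few compounds, and the source may have more. Where it says the series, first, only, none or still open, it means among the compounds named here.

Three compounds built on a shared core were tested in a functional assay on MDA-MB-436 cells (Homo sapiens) for antiproliferative activity, read by MTT assay, with a stated time of 48 h; a lower number here means a stronger inhibitor, a higher number a weaker inhibitor. Compound 1 `C=CS(=O)(=O)N1CCN(c2ncnc3sc(-c4ccc(C#N)cc4)cc23)CC1` gives 9170 nM, compound 2 `C=CS(=O)(=O)N1CCN(c2ncnc3sc(-c4ccc(N5CCN(C)CC5)cc4)cc23)[C@@H](C)C1` gives 6920 nM, and compound 3 `COc1ccc(NC(=O)N2CCN(c3ncnc4sc(-c5ccc(N6CCN(C)CC6)cc5)cc34)CC2)cc1` gives 30100 nM, the highest number of the three; its gaps to compound 1, the nearest, and to compound 2, the furthest, both lie beyond the usual scatter, so compound 3 is the weakest inhibitor of this set. Compound 4 `CN1CCN(c2ccc(-c3cc4c(N5CCN(C(=O)Nc6cc(C(F)(F)F)ccc6F)CC5)ncnc4s3)cc2)CC1` differs from compound 3 in a single place: 2-fluoro-5-(trifluoromethyl)phenyl in place of 4-methoxyphenyl on an amide-type nitrogen. Among the compounds with values here, no measured pair shows this change, so nothing in the data sets its size. A modest step toward stronger inhibition is expected, a 2.0-fold lower number from compound 3 to compound 4 (0.30 log units; within the scatter), with wide uncertainty either way. Compound 4 is estimated at 15000 nM, in a range from 5000 nM to 45000 nM.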

Compound 4, half-maximal inhibitory concentration: 8840 nM
Compound 4: middle estimate off by 1.7-fold (0.23 log units), on the high side, and the stated range covers the measured number.
By their numbers in this assay, from the lowest: compounds 2, 4 and 1 (each within the scatter of the next); then compound 3.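

In this assay the group on this amide-type nitrogen clearly affects the reading: 2-fluoro-5-(trifluoromethyl)phenyl in place of 4-methoxyphenyl gives a 3.4-fold lower number from compound 3 to compound 4 (0.53 log units; beyond the scatter) as a step beyond the usual scatter. Within the data shown here, the earlier compounds offered no pair differing in one place, so this is the first direct reading of any change in the set, though it rests on a single pair. Nothing available explains this step. Going by these compounds, the fluoro and trifluoromethyl groups enter together, so which of them matters more stays open. Also open, on these data alone, is how a plain phenyl or a cyclohexyl group on this nitrogen would read.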